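The compounds below may be only part of what the source reports. "The series", "measured", "known", "first", "only" and "open" are said of these compounds alone.

In a functional assay on LM7 cells (Homo sapiens) for cytotoxicity, read by MTT assay, with a stated time of 72 h (a higher number here means a weaker inhibitor, a lower number a stronger inhibitor), compound 1 `O=c1cc(CSc2nc3ccccc3s2)oc2ccccc12` returns only a limit of the assay, > 25000 nM. Compound 2 `Cc1nnc(SCc2coc3ccc(Cl)cc3c2=O)o1` gives a measured concentration in this assay, namely 8700 nM. Compound 3 `Cc1ccc2oc(CSc3nc4nc(C)cc(C)n4n3)cc(=O)c2c1` likewise returns only a limit in this assay, > 25000 nM. Within the data shown here, compound 3 therefore stands at the limit of > 25000 nM in this assay, at which 2 of the 3 values shown sit, so no number is known for it; set beside compound 2, the two readings show only that compound 2 yields a concentration whereas compound 3 does not.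

Compound 4 `Cc1cc(C)n2nc(SCc3cc(=O)c4cc(Cl)ccc4o3)nc2n1` differs from compound 3 in one place: chloro in place of methyl on an aromatic carbon. Among the measured compounds shown here, no pair of measured compounds differs in just this way, so the size of this step has not been measured. Compound 2 also carries a chloro on its core and gives a number, while compound 3 with a methyl sits at the limit, but those two compounds differ in more than this single position. The step from compound 3 to compound 4 is expected to be an at least 1.2-fold lower number from compound 3 to compound 4 (0.09 log units; that floor lies within the scatter), a small move toward stronger inhibition that may not rise beyond the usual scatter. For compound 4 the estimate in this assay is 20000 nM, with a range from 7000 nM to 50000 nM, and a fair chance that the assay again reports only a limit.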

Compound 4, half-maximal inhibitory concentration: > 25000 nM
Compound 4 ended at the assay's limit; the forecaster's own chance of this, stated with the estimate: 55%; at least 1.2-fold (0.09 log units) between middle value and limit.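

Compound 3 and compound 4 both sit at a limit in this assay rather than at a number, so the step between them cannot be read: the limit of > 25000 nM in this assay, at which 3 of the 4 values shown sit.

The compounds shown leave open whether chloro in place of methyl on an aromatic carbon changes the strength of inhibition at all, and in which direction.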